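This account rests on a few compounds, and the source may have more. Where it says the series, first, only, none or still open, it means among the compounds named here.

Measured so far:
compound 1 `N=C(N)c1ccc(C(=O)NCC(=O)N2CCN(CC(=O)O)C(=O)[C@@H]2CNC(=O)c2ccc(C(=N)N)cc2)cc1` — 120 nM
compound 2 `N=C(N)Nc1ccc(C(=O)NCC(=O)N2CCN(CC(=O)O)C(=O)[C@@H]2CNC(=O)c2ccc(NC(=N)N)cc2)cc1` — 140 nM

In a functional assay for inhibition, with Cavia porcellus as the target (on this read-out lower numbers stand for stronger inhibition and higher numbers for weaker inhibition), compound 1 gives 120 nM and compound 2 gives 140 nM. Compound 2 holds the highest of the two numbers, though its gap to compound 1 lies within the scatter, so the pair reads as equivalent in this assay. Among the measured compounds shown here, no step between measured compounds that differ in one place is available. Compound 3 `N=C(N)Nc1ccc(C(=O)NC[C@H]2C(=O)N(CC(=O)O)CCN2C(=O)CNC(=O)c2ccc(C(=N)N)cc2)cc1` is not yet measured. It differs from compound 2 in one place: a group of 3 heavy atoms (1 carbon, 2 nitrogen; no ring) in place of a group of 4 heavy atoms (1 carbon, 3 nitrogen; no ring), on an aromatic carbon. One end of compound 3 thereby matches compound 1, the other end stays as in compound 2. Compound 1 at 120 nM and compound 2 at 140 nM sit within the scatter of each other, so no change beyond the scatter is expected. The expected step is a 1.1-fold lower number from compound 2 to compound 3 (0.03 log units; within the scatter). Compound 3 is estimated at 130 nM in this assay, with a range of 60 nM to 280 nM.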

Compound 3, half-maximal inhibitory concentration: 85 nM
Estimate against measurement, compound 3: 1.5-fold (0.18 log units) above; low and high end bracket the measured number.
By their numbers in this assay, from the lowest: compounds 3, 1 and 2 (each within the scatter of the next).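

Working notes on the series: in this assay, the single exchange at one end gives a 1.6-fold lower number from compound 2 to compound 3 (0.22 log units; within the scatter), and the opposite exchange at the other end gives a 1.4-fold lower number from compound 1 to compound 3 (0.15 log units; within the scatter). Compound 1 and compound 2 differ at both ends, whereas these steps read each end alone: on an aromatic carbon para to a large group, the group of 3 heavy atoms (1 carbon, 2 nitrogen; no ring) and the group of 4 heavy atoms (1 carbon, 3 nitrogen; no ring) stay within the scatter at either end. No supporting data are available to explain this outcome.

The compounds shown leave open whether a primary amine or a nitrile on the same aromatic carbon would also stay within the scatter. They also leave open whether a longer chain between the ring and either group, or an ester in place of the carboxylic acid, would shift the number.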